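Pyridin-4-yl for 4-fluorophenyl on a benzimidazole inhibitor

The source may hold more compounds than are shown below. What is called first, only, known or untested is meant among the compounds shown, and "the series" means these compounds.

Measured compounds:
compound 1 `CCS(=O)(=O)c1ccc2nc(-c3ccc(-c4ccccc4F)cc3)[nH]c2c1` gives 1250 nM
compound 2 `CS(=O)(=O)c1ccc2nc(-c3ccc(-c4ccc(F)cc4)cc3)[nH]c2c1` gives 25 nM

In an assay on isolated protein for inhibition of acyl-CoA desaturase 1 (Rattus norvegicus) (a higher number here means a weaker inhibitor, a lower number a stronger inhibitor), compound 2 stands at the lower of the two numbers, with compound 1 giving a value that lies well beyond the usual scatter above it. Compound 3 `CS(=O)(=O)c1ccc2nc(-c3ccc(-c4ccncc4)cc3)[nH]c2c1` has not been measured in this assay. It differs from compound 2 in a single place: pyridin-4-yl in place of 4-fluorophenyl on an aromatic carbon. Going by the values given here, no measured pair shows this exact exchange, so its effect must be read as an open question. On the basis of the value of compound 2 alone, compound 3 is expected to land somewhat above it, with a step of a 2.4-fold higher number from compound 2 to compound 3 (0.38 log units; beyond the scatter) that may or may not rise beyond the scatter. The estimate for compound 3 in this assay is 60 nM, in a range from 15 nM to 300 nM.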

Compound 3, half-maximal inhibitory concentration: 2470 nM
Beside the measured number, compound 3's estimate is 41-fold (1.61 log units) below it; measured number above the stated range.
By their numbers in this assay, from the lowest: compound 2; then compounds 1 and 3 (each within the scatter of the next).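

In this assay, going by these compounds alone, pyridin-4-yl in place of 4-fluorophenyl on this aromatic carbon gives a 99-fold higher number from compound 2 to compound 3 (1.99 log units; beyond the scatter), a large step and the first single-place change that can be read. It shows that this position does not accept every six-membered aromatic ring alike: a ring of carbon only that bears fluorine and a ring with one hetero atom give very different numbers, although the groups differ little in heavy-atom count. No available evidence bears on why the step is so large.

The compounds shown leave open how much of the step belongs to the ring nitrogen and how much to the loss of the fluorine, since plain phenyl is not among them. They also leave open how pyridin-3-yl, or a phenyl ring bearing a methoxy group or an amine, would fare at this position.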